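Methoxy to Chloro: What to Expect for Compound 4

The source may hold more compounds than are shown below. What is called first, only, known or untested is meant among the compounds shown, and "the series" means these compounds.

Measured in an ADME assay on HEK-293T cells (Homo sapiens) for cytotoxicity, read by CCK-8 assay, with a stated time of 48 h; a higher number here means that more compound is tolerated, a lower number that less compound is tolerated:
Compound 1 `COc1ccc2[nH]cc(SCC(=O)Nc3ccc(Cl)c(Cl)c3)c2c1` gives 61800 nM.
Compound 2 `Cn1cc(SCC(=O)Nc2cccc(Cl)c2Cl)c2ccccc21` gives > 100000 nM, a limit of the assay.
Compound 3 `Cn1cc([S+]([O-])CC(=O)Nc2ccc(Cl)cc2)c2ccccc21` gives > 100000 nM, a limit of the assay.

Among these three, compound 1 is the only one whose tolerance is given as an actual number. Compound 2 sits at a limit, meaning only that the assay reported no number for it. The same holds for compound 3, which also sits at a limit. Two of the three values thus rest at the limit of > 100000 nM in this assay, at which 2 of the 3 values shown sit, so no measured step between any two of these compounds can be described, and the single number for compound 1 stands on its own.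

Compound 4 `O=C(CSc1c[nH]c2ccc(Cl)cc12)Nc1ccc(Cl)c(Cl)c1` is the compound still to be measured. It differs from compound 1 by chloro in place of methoxy on an aromatic carbon. Going by the values given here, no pair of measured compounds shows what this exchange does in this assay, so the expectation can only be cautious. In this assay compound 4 is expected to give about 70000 nM, with a plausible range from 30000 nM to 150000 nM. That estimate means a step of a 1.1-fold higher number from compound 1 to compound 4 (0.05 log units; within the scatter), which is expected to stay within the usual scatter of repeated measurements rather than mark a real change.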

Compound 4, half-maximal cytotoxic concentration: 42700 nM
Estimate against measurement, compound 4: 1.6-fold (0.21 log units) above; the range from low to high includes it.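

In this assay, going by these compounds alone, the exchange of methoxy for chloro gives a 1.4-fold lower number from compound 1 to compound 4 (0.16 log units; within the scatter) and so provides the first step between two compounds that differ in one place and both carry an actual number. Within the data shown here, until now, nothing could be said about this aromatic carbon of the shared core, since no measured pair touched it. The step now shows that, with the rest of the molecule unchanged, methoxy and chloro cannot be told apart at this position in this assay, even though the exchange removes a hydrogen-bond acceptor and goes from two heavy atoms to one.

From the compounds shown here alone, whether this position tolerates any group equally well remains open, as a single exchange between two groups cannot show it, and an amine, a carboxylic acid or a longer chain such as butoxy on the same carbon could behave quite differently. Compounds 2 and 3 differ from compound 1 in more than one place, so they add no step, and each of them stands only at a limit of the assay: the limit of > 100000 nM in this assay, at which 2 of the 4 values shown sit.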